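A few compounds are considered here, and "the series" means these few. Any claim that something is new, unique, unknown or untested is made for them only; others in the source may bear on it.

Compound 1 `Cc1ccccc1-n1c(Nc2nc(-c3ccc(Br)cc3)cs2)n[nH]c1=S` is the reference point of this small set: in a functional assay on the whole organism (strain Swiss albino) for inhibition, with Mus musculus as the target, with a stated time of 0.5 h (a lower number here means that less compound is needed, a higher number that more compound is needed for the effect), compound 1 gives 30 mg/kg. Compound 2 `Cc1ccccc1-n1c(Nc2nc(-c3ccc([N+](=O)[O-])cc3)cs2)n[nH]c1=S` carries nitro in place of bromo on an aromatic carbon and gives 100 mg/kg, which is a 3.3-fold higher number from compound 1 to compound 2 (0.52 log units; beyond the scatter). Compound 3 `Cc1ccc(-n2c(Nc3nc(-c4ccc(Br)cc4)cs3)n[nH]c2=S)cc1` differs from compound 1 by 4-methylphenyl in place of 2-methylphenyl on an aromatic nitrogen; in this assay compound 3 gives 100 mg/kg, likewise a 3.3-fold higher number from compound 1 to compound 3 (0.52 log units; beyond the scatter); compound 3 and compound 2 sit level at the digits measured.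

Compound 4 `Cc1ccc(-n2c(Nc3nc(-c4ccc([N+](=O)[O-])cc4)cs3)n[nH]c2=S)cc1` is not yet measured. It differs from compound 3 by nitro in place of bromo on an aromatic carbon, the same change already made from compound 1 to compound 2, and the two cores differ by 4-methylphenyl in place of 2-methylphenyl on an aromatic nitrogen. Because that earlier step was a 3.3-fold higher number from compound 1 to compound 2 (0.52 log units; beyond the scatter), a step of comparable size is expected here, though compound 3 already stands at the higher end of the set. Compound 4 is therefore expected to need 300 mg/kg, a move of a 3.0-fold higher number from compound 3 to compound 4 (0.48 log units; beyond the scatter), within 100 mg/kg to 1000 mg/kg.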

Compound 4, minimum effective dose: 100 mg/kg
Beside the measured number, compound 4's estimate is 3.0-fold (0.48 log units) above it; measured number inside the range.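

Nitro in place of bromo gives no change at the digits printed from compound 3 to compound 4 (within the scatter) in this assay, so this change does not carry over at the same size from the core of compound 1 to the core of compound 3: the same change on two cores in this assay, a 3.3-fold higher number (0.52 log units; beyond the scatter) from compound 1 to compound 2 and no change at the digits printed (within the scatter) from compound 3 to compound 4, 3.3-fold (0.52 log units) apart, beyond the scatter of two such steps

Likewise, 4-methylphenyl in place of 2-methylphenyl gives no change at the digits printed from compound 2 to compound 4 (within the scatter), so that change also depends on the group already present: the same change on two cores in this assay, a 3.3-fold higher number (0.52 log units; beyond the scatter) from compound 1 to compound 3 and no change at the digits printed (within the scatter) from compound 2 to compound 4, 3.3-fold (0.52 log units) apart, beyond the scatter of two such steps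

This shows that the two changes do not add up across these four compounds, but it does not show what lies behind this, and a single pair per change cannot predict the result on another core.

The compounds shown leave open what an amine or a carboxylic acid in the place of bromo would give. They also leave open what a longer chain in the place of methyl would give.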